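The compounds below may be only part of what the source reports. "The series", "measured", "known", "first", "only" and "open" are said of these compounds alone.

Measured so far in a functional assay on PANC-1 cells (Homo sapiens) for inhibition, read by MTT assay, with a stated time of 24 h, tested at 10 uM; a lower number here means less inhibition, a higher number more inhibition at the concentration tested (going by the name of the read-out):
- compound 1, `CC(C)=CCC1Cc2c(O)cc(=O)n(CCCO)c2CC1(C)C`, gives 25.6%
- compound 2, `CC(C)=CCC1Cc2c(OCCCNS(=O)(=O)c3ccc(Cl)cc3)cc(=O)n(CCCO)c2CC1(C)C`, gives 24.7%
- compound 3, `COc1ccc(C(=O)NCCCOc2cc(=O)n(CCCO)c3c2CC(CC=C(C)C)C(C)(C)C3)cc1`, gives 55.5%

Compound 3 stands highest of the three in this assay; compound 1 is nearest to it and compound 2 furthest, and both sit lower by more than the usual scatter. The only single-point step among these compounds is a number 30.8 percentage points higher from compound 2 to compound 3 (beyond the scatter), in which a (4-methoxyphenyl)carbonyl replaced a (4-chlorophenyl)sulfonyl on an amine nitrogen.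

Compound 4, `CC(C)=CCC1Cc2c(OCCCNC(=O)c3cccs3)cc(=O)n(CCCO)c2CC1(C)C`, keeps the carbonyl and the amine nitrogen of compound 3 and changes only the ring on the carbonyl carbon: thiophen-2-yl in place of 4-methoxyphenyl on a carbonyl carbon. For the measured compounds named here, no measured step exchanges one aromatic ring for another at this carbonyl carbon, so the step from compound 2 to compound 3 does not bear directly on this change, and there is no basis for expecting a step beyond the scatter in this assay in either direction. Compound 4 is therefore expected to give about 49% in this assay, with a range from 32% to 66%. The step this estimate means, a number 6.5 percentage points lower from compound 3 to compound 4 (within the scatter), is expected to be small and within the scatter.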

Compound 4, a percentage reported as inhibition, at one concentration (the size of the read-out at that concentration, not a potency): 33.6%
Compound 4: the middle estimate sits 15.4 percentage points above what was measured; the range from low to high includes it.
By their numbers in this assay, from the lowest: compounds 2, 1 and 4 (each within the scatter of the next); then compound 3.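

Swapping only the ring on the carbonyl carbon is enough to move the result: the change to thiophen-2-yl gives a number 21.9 percentage points lower from compound 3 to compound 4 (beyond the scatter) in this assay, so this position responds to the aromatic ring itself, and not just to whether a carbonyl or a sulfonyl sits on the amine nitrogen. The thiophene amide also does not stand apart from the other two compounds, with a number 8.9 percentage points higher from compound 2 to compound 4 (within the scatter) and a number 8 percentage points higher from compound 1 to compound 4 (within the scatter), which leaves compound 3 alone above the rest. Nothing available here explains the difference between the two rings.

Still open, on these data alone, is whether the methoxy group or the six-membered ring accounts for the higher number of compound 3. A plain phenyl or a 4-hydroxyphenyl on the same carbonyl carbon could separate those two possibilities.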